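The source may report more compounds than this note shows. Statements on the series, on what has been measured and on what is new or still open speak of the compounds shown alone.

Measured so far in an assay on HeLa cells for inhibition of sphingosine-1-phosphate transporter SPNS2 (Mus musculus), read by LC-MS, tested at 2 uM; a lower number here means less inhibition, a higher number more inhibition at the concentration tested (going by the name of the read-out):
Compound 1 `CCCCCCCCCCc1ccc(-c2noc(C3CNC3)n2)cc1` gives 65%.
Compound 2 `CCCCCCCCCCc1ccc(-c2noc(CCCN)n2)cc1` gives 67%.
Compound 3 `CCCCCCCCCCc1ccc(-c2noc(CC3CCNC3)n2)cc1` gives 44%.

Compound 3 stands lowest of the three in this assay; its nearest neighbour is compound 1, with a number 21 percentage points lower from compound 1 to compound 3 (beyond the scatter), and compound 2 lies further off, with a number 23 percentage points lower from compound 2 to compound 3 (beyond the scatter). Compound 4 `CCCCCCCCCCc1ccc(-c2noc([C@H]3CCCN3)n2)cc1` differs from compound 3 in one place: pyrrolidin-2-yl in place of (pyrrolidin-3-yl)methyl on an aromatic carbon. The two steps that bear on this move both end at compound 3 and both were modest drops, so the return to a ring bound directly to the aromatic carbon, as in compound 1, is expected to recover most of that loss. Compound 4 is therefore expected to give 58%, with a range from 38% to 78%, an expected step of a number 14 percentage points higher from compound 3 to compound 4 (beyond the scatter).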

Compound 4, a percentage reported as inhibition, at one concentration (the size of the read-out at that concentration, not a potency): 12%
Estimate against measurement, compound 4: 46 percentage points above, and the stated range ends above it.
By their numbers in this assay, from the lowest: compound 4; then compound 3; then compounds 1 and 2 (each within the scatter of the next).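

In this assay a ring bound directly to the aromatic carbon next to the ring oxygen does not by itself keep the number high, as pyrrolidin-2-yl falls short of (pyrrolidin-3-yl)methyl (a number 32 percentage points lower from compound 3 to compound 4 (beyond the scatter)), azetidin-3-yl (a number 53 percentage points lower from compound 1 to compound 4 (beyond the scatter)) and 3-aminopropyl (a number 55 percentage points lower from compound 2 to compound 4 (beyond the scatter)). For the compounds shown here, this position therefore separates two directly bound rings, azetidin-3-yl and pyrrolidin-2-yl, by far more than the earlier steps did. No measurement at hand accounts for this drop. The compounds shown leave open whether pyrrolidin-2-yl with the opposite stereocentre, or a pyrrolidin-3-yl or piperidin-4-yl ring bound directly at this carbon, would stay as low.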